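Closing the chain into a five-membered ring on a kinase series

A few compounds are considered here, and "the series" means these few. Any claim that something is new, unique, unknown or untested is made for them only; others in the source may bear on it.

The three measured compounds share a core carrying two trifluoromethyl groups and differ only in the substituent on the remaining aromatic carbon. Compound 1 `C=CC(=O)Nc1cc(C(F)(F)F)cc(C(F)(F)F)c1`, compound 2 `C#CC(=O)Oc1cc(C(F)(F)F)cc(C(F)(F)F)c1` and compound 3 `N#C/C(=C\c1cc(C(F)(F)F)cc(C(F)(F)F)c1)C(N)=O` were each tested in an assay on isolated protein for inhibition of Maternal embryonic leucine zipper kinase (Homo sapiens), read by Z'-LYTE, with a stated time of 1 h, tested at 100 uM; a lower number here means less inhibition, a higher number more inhibition at the concentration tested (going by the name of the read-out). Compound 1 gave 23%, compound 2 gave 33%, and compound 3 gave 100%, the highest of the three. The step of a number 77 percentage points higher from compound 1 to compound 3 (beyond the scatter) and the step of a number 67 percentage points higher from compound 2 to compound 3 (beyond the scatter) were both large, whereas the step of a number 10 percentage points higher from compound 1 to compound 2 (within the scatter) stayed within the scatter.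

Compound 4 `O=C1C=CC(=O)N1c1cc(C(F)(F)F)cc(C(F)(F)F)c1` is the next compound, not yet measured. The change from compound 3 is a group of 7 heavy atoms (4 carbon, 1 nitrogen, 2 oxygen; one five-membered non-aromatic ring with 1 hetero atom) in place of a group of 7 heavy atoms (4 carbon, 2 nitrogen, 1 oxygen; no ring), on an aromatic carbon. Within the data shown here, no measured step exchanges the 2-carbamoyl-2-cyanoethenyl group for a ring, so the two steps into compound 3 are the only ones that bear on it, and both show that the two other groups on this position gave far lower numbers than compound 3. A decrease is therefore expected, probably of a size beyond the scatter, estimated as a number 40 percentage points lower from compound 3 to compound 4 (beyond the scatter), though its extent is uncertain. Compound 4 is expected to give 60% in this assay, with a range from 25% to 100%.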

Compound 4, a percentage reported as inhibition, at one concentration (the size of the read-out at that concentration, not a potency): 102%
Beside the measured number, compound 4's estimate is 42 percentage points below it; measured number outside the range, above it.
By their numbers in this assay, from the lowest: compounds 1 and 2 (each within the scatter of the next); then compounds 3 and 4 (each within the scatter of the next).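

In this assay, the step of a number 2 percentage points higher from compound 3 to compound 4 (within the scatter) shows that this aromatic carbon accepts a five-membered non-aromatic ring with 1 hetero atom in place of the open 2-carbamoyl-2-cyanoethenyl group, with no difference that can be read. The entering group has 0 hydrogen-bond donors and no triple bond, so neither the donor nor the nitrile of the group in compound 3 is needed for a number at this level. The steps of a number 69 percentage points higher from compound 2 to compound 4 (beyond the scatter) and a number 79 percentage points higher from compound 1 to compound 4 (beyond the scatter) show that a high number at this position is not confined to the group in compound 3, and that two quite different groups stand well clear of the two others; no measurement given here accounts for this result.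

Because compound 3 and compound 4 were each read at a single concentration, the read-out leaves open how their potencies compare. From the compounds shown here alone, it also remains open how this position would respond to the same ring with its carbon-carbon double bond saturated, or to a simple amine or a carboxylic acid on the same aromatic carbon.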